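Amino for Chloro: the Same Change on Two Cores

The compounds below may be only part of what the source reports. "The series", "measured", "known", "first", "only" and "open" are said of these compounds alone.

The three measured compounds, all tested in a functional assay on HT-29 cells (Homo sapiens) for cytotoxicity, read by sulforhodamine B assay, with a stated time of 48 h; on this read-out higher numbers stand for weaker inhibition of growth and lower numbers for stronger inhibition of growth:

Compound 1 `Nc1nc(Cl)c2ncn(Cc3ccc(CCl)cc3)c2n1` — 27500 nM
Compound 2 `ClCc1cccc(Cn2cnc3c(Cl)nc(Cl)nc32)c1` — only a limit of the assay, > 100000 nM
Compound 3 `ClCc1ccc(Cn2cnc3c(Cl)nc(Cl)nc32)cc1` — only a limit of the assay, > 100000 nM

Compound 3 and compound 1 differ in one place, (amino in place of chloro on an aromatic carbon). That change gave an at least 3.6-fold lower number from compound 3 to compound 1 (0.56 log units; beyond the scatter). Compound 2 and compound 3 are built from the same atoms joined differently; the difference between the two cores is not broken down here. Two of the three values reported sit at the limit of > 100000 nM in this assay, at which 2 of the 3 values shown sit, so the step from compound 3 can only be given as a lower bound.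

Compound 4 `Nc1nc(Cl)c2ncn(Cc3cccc(CCl)c3)c2n1` has not yet been measured in this assay. It stands to compound 2 as compound 1 stands to compound 3: amino in place of chloro on an aromatic carbon. The change is the same, down to the wording of where it sits. Among the measured compounds shown here, compound 2 is known only as a limit, so the earlier step is the only guide to its size. Because compound 3 to compound 1 gave an at least 3.6-fold lower number from compound 3 to compound 1 (0.56 log units; beyond the scatter), compound 4 is expected to move from compound 2 by about an at least 2.5-fold lower number from compound 2 to compound 4 (0.39 log units; beyond the scatter), with the caveat that a move of that size from a limit may still land at the limit. Compound 4 is therefore estimated at 40000 nM in this assay, within a range from 12000 nM to 130000 nM.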

Compound 4, concentration for total growth inhibition: 9770 nM
Compound 4: middle estimate off by 4.1-fold (0.61 log units), on the high side; the measured number lies below the stated range.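

In this assay, amino in place of chloro on an aromatic carbon, between two ring nitrogen atoms, again gave a lower number on the second core, with an at least 10-fold lower number from compound 2 to compound 4 (1.01 log units; beyond the scatter). The change therefore pointed the same way on both cores, pointing to stronger inhibition of growth in each of the two pairs, although two pairs are all that this rests on and the sizes cannot be set against each other: the same change on two cores in this assay, an at least 3.6-fold lower number (0.56 log units; beyond the scatter) from compound 3 to compound 1 and an at least 10-fold lower number (1.01 log units; beyond the scatter) from compound 2 to compound 4; the limit leaves it open whether they differ What the pairs do not show is the true size of either step, or whether one core responds more strongly to the change than the other, since both chloro compounds stand at a limit and not at a number: the limit of > 100000 nM in this assay, at which 2 of the 4 values shown sit.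

The compounds shown leave open whether a different group at the same place, such as a methylamino or a methoxy group, would lower the number on either core as amino does. They also leave open whether the amino compounds would keep their values if the chloromethyl group, which all four compounds carry, gave way to a hydroxymethyl group.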